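Moving the Chlorine Around the Pendant Phenyl Ring

The source may report more compounds than this note shows. Statements on the series, on what has been measured and on what is new or still open speak of the compounds shown alone.

Compound 1 `CC(C)c1cccc(C(C)C)c1NC(=O)Nc1nc2ccccc2n1-c1ccccc1Cl` and compound 2 `CC(C)c1cccc(C(C)C)c1NC(=O)Nc1nc2ccccc2n1-c1cccc(Cl)c1` share one core and differ only in where the chlorine sits on the phenyl ring attached to an aromatic nitrogen. In an assay on isolated protein for displacement of a labelled ligand from acyl-CoA:cholesterol acyltransferase (Oryctolagus cuniculus) (a lower number here means a stronger inhibitor, a higher number a weaker inhibitor), compound 1 gives 18 nM, and compound 2 gives 20 nM. For the measured compounds named here, compound 2 therefore holds the higher of the two numbers measured so far, but the step of a 1.1-fold higher number from compound 1 to compound 2 (0.05 log units; within the scatter) lies within the scatter, so the two compounds cannot be told apart on these data. Compound 3 `CC(C)c1cccc(C(C)C)c1NC(=O)Nc1nc2ccccc2n1-c1ccc(Cl)cc1` carries the change (4-chlorophenyl in place of 3-chlorophenyl on an aromatic nitrogen). Going by the values given here, the only measured step that bears on this change is the earlier move of the chlorine from 2-chlorophenyl to 3-chlorophenyl, which left the number in this assay where it was. Since one shift of the chlorine around that ring produced nothing beyond the scatter, a second shift is expected to behave the same way, with at most a slight drift toward a higher number. Compound 3 is thus estimated at 25 nM, within 10 nM to 65 nM, which corresponds to an expected step of a 1.3-fold higher number from compound 2 to compound 3 (0.10 log units; within the scatter).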

Compound 3, half-maximal inhibitory concentration: 280 nM
Compound 3: middle estimate off by 11-fold (1.05 log units), on the low side; the measured number lies above the stated range.
By their numbers in this assay, from the lowest: compounds 1 and 2 (each within the scatter of the next); then compound 3.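

In this assay, the place of the chlorine on the phenyl ring does matter, which the earlier pair gave no sign of: 4-chlorophenyl in place of 3-chlorophenyl gives a large step (a 14-fold higher number from compound 2 to compound 3 (1.15 log units; beyond the scatter)), and 4-chlorophenyl in place of 2-chlorophenyl gives one of similar size (a 16-fold higher number from compound 1 to compound 3 (1.19 log units; beyond the scatter)). The insensitivity seen between compound 1 and compound 2 therefore holds for 2-chlorophenyl and 3-chlorophenyl only and does not extend to 4-chlorophenyl, which makes compound 3 the weakest inhibitor of the three, with its steps to both others beyond the scatter. Nothing available here bears on why this one shift of the chlorine separates compound 3 from the other two.

From the compounds shown here alone, it remains open whether the higher number belongs to chlorine in particular or to any group at that place on the ring, such as a methyl, a methoxy or an amine. Going by these compounds, it also remains open how a phenyl ring with no chlorine at all would compare with these three compounds.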